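Swapping Methoxy for Phenyl in an Antiproliferative Series

The source may report more compounds than this note shows. Statements on the series, on what has been measured and on what is new or still open speak of the compounds shown alone.

In a functional assay on SK-OV-3 cells (Homo sapiens) for antiproliferative activity, read by MTT assay, with a stated time of 72 h (a lower number here means a stronger inhibitor, a higher number a weaker inhibitor), three compounds with the same core have been measured so far. Compound 1 `O=C(CCc1cccc2c1B(O)OC2)Nc1ccccc1` has hydrogen at the aromatic carbon that varies and gives 200 nM as the lowest number. Compound 2 `O=C(CCc1cccc2c1B(O)OC2)Nc1ccc(Cl)cc1` has chloro there and gives 5000 nM as the highest. Compound 3 `COc1ccc(NC(=O)CCc2cccc3c2B(O)OC3)cc1` has methoxy there and gives 900 nM as the middle number. Compound 4 `O=C(CCc1cccc2c1B(O)OC2)Nc1ccc(-c2ccccc2)cc1` has phenyl in place of methoxy on an aromatic carbon as its only difference. Going by the values given here, three measured steps bear on this. Chloro in place of hydrogen gave a 25-fold higher number from compound 1 to compound 2 (1.40 log units; beyond the scatter) as a large step, methoxy in place of hydrogen gave a 4.5-fold higher number from compound 1 to compound 3 (0.65 log units; beyond the scatter) as a modest one, and methoxy in place of chloro gave a 5.6-fold lower number from compound 2 to compound 3 (0.74 log units; beyond the scatter) as another modest one. Both substituted compounds thus stand above compound 1 (200 nM), but no ring has been tried at this place, so the forecast stays loose. A modest upward step is expected, estimated as a 3.3-fold higher number from compound 3 to compound 4 (0.52 log units; beyond the scatter) in this assay for this change. Compound 4 is expected near 3000 nM (800 nM to 10000 nM).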

Compound 4, half-maximal inhibitory concentration: 48000 nM
The estimate for compound 4 lay 16-fold (1.20 log units) below the measured number; measured number above the stated range.
By their numbers in this assay, from the lowest: compound 1; then compound 3; then compound 2; then compound 4.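

A ring at this position raises the number further than methoxy or chloro did. Phenyl in place of methoxy gives (a 53-fold higher number from compound 3 to compound 4 (1.73 log units; beyond the scatter)), phenyl in place of chloro gives (a 9.6-fold higher number from compound 2 to compound 4 (0.98 log units; beyond the scatter)), and phenyl in place of hydrogen gives (a 240-fold higher number from compound 1 to compound 4 (2.38 log units; beyond the scatter)), which makes compound 4 the weakest of the four. Among these compounds no group has yet improved on the plain hydrogen of compound 1, and nothing at hand explains the size of the rise.

Going by these compounds, whether an amine or a carboxylic acid at this position would match hydrogen remains open. So does whether a phenyl elsewhere on this aromatic ring would raise the number as sharply.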